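The source may report more compounds than this note shows. Statements on the series, on what has been measured and on what is new or still open speak of the compounds shown alone.

In an ADME assay on microsomes from liver (Mus musculus) for metabolic stability, read by HPLC, using NADPH, with a stated time of 60 min, tested at 1 uM, in the presence of a further agent that is not named here (a higher number here means that the compound lasts longer, a lower number that the compound disappears faster), compound 1 `Cc1cc(OC(C)C)cc(C(=O)NNS(=O)(=O)c2ccccc2F)c1` gives < 0.0334 h, which is a limit of the assay and not a number. Within the data shown here, compound 2 `Cc1cc(C(=O)NNS(=O)(=O)c2ccccc2F)cc(-n2cc(F)cn2)c1` gives 0.0667 h, the only actual number so far. Compound 3 `CCOc1cc(C)cc(C(=O)NNS(=O)(=O)c2ccccc2F)c1` carries ethoxy in place of 4-fluoro-1H-pyrazol-1-yl on an aromatic carbon. Ethoxy resembles the isopropoxy that left in the one measured step bearing on this change, an at least 1.9-fold higher number from compound 1 to compound 2 (0.30 log units; that floor lies within the scatter), so a move back of similar size, towards a lower number, is expected in this assay. The estimated change is a 2.2-fold lower number from compound 2 to compound 3 (0.35 log units; beyond the scatter). For compound 3 the estimated half-life is 0.03 h, with an expected range of 0.015 h to 0.07 h.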

Compound 3, half-life: < 0.0334 h
Compound 3: no number, only a limit; the forecaster's own chance of this, stated with the estimate: 60%; the middle value is on the limit's open side.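

In this assay, compound 3 gives only a limit, not a number, so ethoxy, like isopropoxy in compound 1, leaves no readable half-life at this position. Putting ethoxy in place of 4-fluoro-1H-pyrazol-1-yl gives an at least 1.9-fold lower number from compound 2 to compound 3 (0.30 log units; that floor lies within the scatter). Compound 1 and compound 3 cannot be compared with each other, because both rest on the same limit: the limit of < 0.0334 h in this assay, at which 2 of the 3 values shown sit.

On these data alone, how far past that limit either compound lies stays unknown. As far as these compounds go, whether an amine, a methoxy group or a different five-membered aromatic ring at this position would give a readable half-life also stays open.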